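The source may hold more compounds than are shown below. What is called first, only, known or untested is meant among the compounds shown, and "the series" means these compounds.

Working notes on the series, measured in a functional assay on HCT-116 cells (Homo sapiens) for antiproliferative activity, read by MTT assay, with a stated time of 72 h (on this read-out higher numbers stand for weaker inhibition and lower numbers for stronger inhibition), so far:

- compound 1 `COc1cc(CCc2ccccn2)cc(OC)c1O` gives 3060 nM
- compound 2 `COc1cc(CCc2ccncc2)cc(OC)c1O` gives 3740 nM

Compound 2 stands level with compound 1 within the scatter, the measured step being a 1.2-fold higher number from compound 1 to compound 2 (0.09 log units; within the scatter). These two values are all that the series offers so far.

Compound 3 `COc1cc(CCc2ccccc2)cc(OC)c1O` has not yet been measured. The change to it from compound 2 is phenyl in place of pyridin-4-yl on a saturated chain carbon, two bonds along the chain from an aromatic carbon.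

Among the measured compounds shown here, only one measured step bears on this place, the swap of pyridin-2-yl for pyridin-4-yl, and it stayed within the scatter. For the measured compounds named here, it is indirect evidence, as no compound with phenyl at this place has a value yet. With so little to go on, no step beyond the scatter is expected in this assay, and no direction can be argued with confidence. The expected step is a 1.2-fold lower number from compound 2 to compound 3 (0.10 log units; within the scatter). The wide range below reflects this thin basis. For compound 3 the estimated value is 3000 nM, with an expected range from 1000 nM to 9000 nM.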

Compound 3, half-maximal inhibitory concentration: 530 nM
The estimate for compound 3 lay 5.7-fold (0.75 log units) above the measured number; the whole stated range lies above it.
By their numbers in this assay, from the lowest: compound 3; then compounds 1 and 2 (each within the scatter of the next).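

In this assay, the place on a saturated chain carbon, two bonds along the chain from an aromatic carbon, now shows a response beyond the scatter, which the exchange of the two pyridines did not show: phenyl in place of pyridin-4-yl gives a 7.1-fold lower number from compound 2 to compound 3 (0.85 log units; beyond the scatter), and phenyl in place of pyridin-2-yl gives a 5.8-fold lower number from compound 1 to compound 3 (0.76 log units; beyond the scatter). Both changes replace a six-membered aromatic ring with a hetero atom by one of carbon only, and they run in the same direction, leaving compound 3 with the lowest number of the three, while a 1.2-fold higher number from compound 1 to compound 2 (0.09 log units; within the scatter) separates the two pyridines by no more than the scatter. No measurement among the data shown accounts for this difference.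

The compounds shown leave open whether the lower number is specific to unsubstituted phenyl, as they include no pyridin-3-yl, no phenyl bearing fluorine or methoxy, and no saturated ring such as cyclohexyl at this place. They also leave open how the phenyl result would hold with a longer chain or with an amide in place of the saturated chain.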